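The source may hold more compounds than are shown below. What is called first, only, known or untested is meant among the compounds shown, and "the series" means these compounds.

Of the compounds shown here, three that share a core have been measured in a functional assay (Platelet, plasma) for inhibition, with Homo sapiens as the target; on this read-out higher numbers stand for weaker inhibition and lower numbers for stronger inhibition. Compound 1 (`N#Cc1cc2c(nc1N1CCC(F)(C(=O)NS(=O)(=O)Cc3ccc(Cl)cc3)CC1)COC2=O`) gives 37200 nM, compound 2 (`CC(c1ccccc1)S(=O)(=O)NC(=O)C1CCN(c2nc3c(cc2C#N)C(=O)OC3)CC1`) gives 4160 nM, and compound 3 (`N#Cc1ccc(CS(=O)(=O)NC(=O)C2CCN(c3nc4c(cc3C#N)C(=O)OC4)CC2)cc1`) gives 8900 nM, the middle number of the three. Compound 4 (`N#Cc1cc2c(nc1N1CCC(C(=O)NS(=O)(=O)Cc3ccc(Cl)cc3)CC1)COC2=O`) has not been measured yet. It differs from compound 3 in one place, with chloro in place of cyano on an aromatic carbon, para to a large group, so that 4-cyanobenzyl becomes 4-chlorobenzyl (chloro in place of cyano on an aromatic carbon). One measured step involves the group on the sulfonyl sulfur: a 2.1-fold higher number from compound 2 to compound 3 (0.33 log units; beyond the scatter), which is modest. Compound 1 also carries 4-chlorobenzyl, but it differs from compound 3 in a further place, so the value of compound 1, 37200 nM, offers only a loose hint towards a higher number. A step no larger than the modest one is therefore expected, most likely none beyond the scatter and with no firm direction. The expected change is a 1.1-fold lower number from compound 3 to compound 4 (0.05 log units; within the scatter). For compound 4 the estimated value is 8000 nM, with an expected range of 2500 nM to 25000 nM.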

Compound 4, half-maximal inhibitory concentration: 4420 nM
Compound 4: middle estimate off by 1.8-fold (0.26 log units), on the high side, within the range that was stated.
By their numbers in this assay, from the lowest: compounds 2, 4 and 3 (each within the scatter of the next, the first and the last beyond it); then compound 1.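

In this assay, the change at this carbon, para to a large group, gives a 2.0-fold lower number from compound 3 to compound 4 (0.30 log units; within the scatter), so chloro and cyano cannot be told apart here. Likewise, a 1.1-fold higher number from compound 2 to compound 4 (0.03 log units; within the scatter) places 4-chlorobenzyl and 1-phenylethyl on the sulfonyl sulfur within the scatter of each other, even though 4-cyanobenzyl and 1-phenylethyl were just separated. The step that stands out is an 8.4-fold lower number from compound 1 to compound 4 (0.93 log units; beyond the scatter), with hydrogen in place of fluoro on a saturated ring carbon, so the high number of compound 1 goes with the fluoro and not with the 4-chlorobenzyl group it shares with compound 4.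

No measurement at hand explains any of these steps. Still open, from the compounds shown here alone, are how a methoxy group or an amine would read at this aromatic carbon, and whether the fluoro step would hold with 4-cyanobenzyl or 1-phenylethyl on the sulfur.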